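A Hydroxy Group Enters the Imine Compound

The compounds below may be only part of what the source reports. "The series", "measured", "known", "first", "only" and "open" are said of these compounds alone.

Compound 2 `C(=N/c1sc2c(c1-c1nc3ccccc3s1)CCCC2)\c1ccccc1` stands at the higher of the two numbers recorded in an ADME assay on cells (Rhabdomyosarcoma cell, Homo sapiens) for cytotoxicity, read by MTT assay, with a stated time of 72 h (on this read-out lower numbers stand for higher toxicity in this test and higher numbers for lower toxicity in this test), where compound 2 gives 71.1 ug/mL. Its nearest neighbour, compound 1 `Nc1sc2c(c1-c1nc3cc(Cl)ccc3s1)CCCC2`, differs from it in more than one place, and in this assay compound 1 gives 43.5 ug/mL; the gap between the two values lies within the scatter of repeated measurements, so the two compounds cannot be placed in any order on this read-out.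

Compound 3 `Oc1ccccc1/C=N/c1sc2c(c1-c1nc3ccccc3s1)CCCC2` is the next compound to be measured in this assay. It differs from compound 2 by a single change: hydroxy in place of hydrogen on an aromatic carbon. Going by the values given here, no step between two measured compounds is available that would show what such a change does here, and nothing in the two measured values speaks for a large shift in either direction. The expected step from compound 2 to compound 3 is therefore a 1.2-fold lower number from compound 2 to compound 3 (0.07 log units; within the scatter), a change not beyond the scatter. Compound 3 is estimated to give 60 ug/mL in this assay, within a range of 25 ug/mL to 150 ug/mL.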

Compound 3, half-maximal cytotoxic concentration: 42.4 ug/mL
Beside the measured number, compound 3's estimate is 1.4-fold (0.15 log units) above it, within the range that was stated.
By their numbers in this assay, from the lowest: compounds 3, 1 and 2 (each within the scatter of the next).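

With this pair the series gains its first comparison that differs in one place: hydroxy in place of hydrogen on an aromatic carbon, ortho to a large group, gives a 1.7-fold lower number from compound 2 to compound 3 (0.22 log units; within the scatter) in this assay. On this read-out the change from phenyl to 2-hydroxyphenyl therefore cannot be told apart from no change at all, since a single added hydroxy group at this position leaves the two compounds within the scatter of repeated measurements. Nothing shown here offers a measured reason for this result or gives any property of the hydroxy group at this position.

From the compounds shown here alone, whether another group on the same aromatic carbon, such as methoxy, an amine or a carboxylic acid, would give a step beyond the scatter remains open, as does whether hydroxy would read the same elsewhere on this ring. Compound 1 differs from compound 3 in more than one place, so it cannot help to settle either question, and the reading of this position rests on one pair alone.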